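Flavone-piperazine amides: methoxy addition on the benzyl group

This account rests on a few compounds, and the source may have more. Where it says the series, first, only, none or still open, it means among the compounds named here.

Compound 1 `CCOC(=O)COc1cc(-c2cc(=O)c3c(O)cc(OCC(=O)N4CCN(Cc5ccc(OC)c(OC)c5OC)CC4)cc3o2)ccc1OC`, compound 2 `COc1ccc(-c2cc(=O)c3c(O)cc(OCC(=O)N4CCN(Cc5ccc(OC)c(OC)c5OC)CC4)cc3o2)cc1OCC(=O)N1CCN(Cc2ccc(OC)c(OC)c2OC)CC1`, compound 3 `CCOC(=O)COc1cc(-c2cc(=O)c3c(O)cc(OCC(=O)N4CCN(Cc5ccc(OC)cc5)CC4)cc3o2)ccc1OC` and compound 4 `CCOC(=O)COc1cc(-c2cc(=O)c3c(O)cc(OCC(=O)N4CCN(Cc5ccc(OC)cc5OC)CC4)cc3o2)ccc1OC` share one core and differ in the substituents on the flanking aryl groups. In an ADME assay on MRC5 cells (Homo sapiens) for cytotoxicity (a lower number here means a stronger inhibitor, a higher number a weaker inhibitor), compound 1 reaches only a limit, > 70000 nM. In this assay compound 2 gives 1000 nM. Compound 3 has no number in this assay: the result is recorded as "not determined" (no result reported). Where compound 3 stands is therefore open; the two compounds that were measured show one value that is a limit of > 70000 nM in this assay, at which 1 of the 3 values shown sits, and one that is a number, and no step between compounds that differ in one place is available.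

The change from compound 3 to compound 4 is methoxy in place of hydrogen on an aromatic carbon, read one bond further out as 4-methoxybenzyl to 2,4-dimethoxybenzyl. Among the compounds with values here, no measured pair in this assay tells what such a change does, so no step beyond the scatter is expected in either direction, and the estimate is anchored only loosely on the weak end seen for compound 1 > 70000 nM. Compound 4 is expected in this assay at about 40000 nM, within a range from 8000 nM to 150000 nM, with a real chance that only a limit is reported.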

Compound 4, half-maximal inhibitory concentration: 5600 nM
For compound 4 the middle estimate is 7.1-fold (0.85 log units) above the measured one, outside the stated range (below it).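

In this assay, within the data shown here, compound 4, with its 2,4-dimethoxybenzyl group, gives 5600 nM, the first number for a compound carrying the ethyl ester side chain. Compound 1 carries one further methoxy on the benzyl ring, and its value of > 70000 nM is a limit. Hydrogen in place of that methoxy gives an at least 12-fold lower number from compound 1 to compound 4 (1.09 log units; beyond the scatter), so within this pair a single methoxy on the benzyl ring moves the number in this assay beyond the scatter, and the true size of the step stays open because its starting value is a limit: the limit of > 70000 nM in this assay, at which 1 of the 4 values shown sits.

Going by these compounds, the step from the 4-methoxybenzyl group of compound 3 to the 2,4-dimethoxybenzyl group cannot be read, so what the methoxy added in compound 4 does on its own remains open. Also open, on these data alone, is whether a chlorine or a hydroxy group on that aromatic carbon, or a carboxylic acid in place of the ethyl ester, would keep the number in this assay close to that of compound 4.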